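The source may hold more compounds than are shown below. What is called first, only, known or untested is meant among the compounds shown, and "the series" means these compounds.

Compound 1 `O=C(O)CC(NC(=O)c1cccc(Br)c1)c1ccccc1`: > 100000 nM (a limit of the assay)
Compound 2 `CC(C)(C)c1ccc(C(CC(=O)O)NS(=O)(=O)c2ccc(OC(F)(F)F)cc2)cc1`: > 100000 nM (a limit of the assay)
Compound 3 `O=C(O)CC(NC(=O)c1ccc(F)cc1)c1ccccc1F`: 72300 nM

Of the three compounds tested in a functional assay on MDA-MB-231 cells (Homo sapiens) for antiproliferative activity, read by MTT assay, with a stated time of 24 h (on this read-out higher numbers stand for weaker inhibition and lower numbers for stronger inhibition), only compound 3 gives a number, 72300 nM. The other two results are not numbers but limits, and the limit of > 100000 nM in this assay, at which 2 of the 3 values shown sit, is the only reference point for placing compound 3.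

Compound 4 `O=C(O)CC(NC(=O)c1cccc(Br)c1)c1ccccc1F` differs from compound 3 in one place, with 3-bromophenyl in place of 4-fluorophenyl on a carbonyl carbon. Going by the values given here, no measured pair isolates this change. Compound 1 carries the same 3-bromophenyl on its carbonyl carbon and shows only a limit, > 100000 nM. On that basis, a small shift towards weaker inhibition in this assay is expected, probably not beyond the usual scatter, with the estimate being a 1.2-fold higher number from compound 3 to compound 4 (0.10 log units; within the scatter). Compound 4 is estimated at 90000 nM, with an expected range of 40000 nM to 200000 nM.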

Compound 4, half-maximal inhibitory concentration: > 100000 nM
Compound 4 was reported as a limit; the forecaster's own chance of this, stated with the estimate: 45%; at least 1.1-fold (0.04 log units) between middle value and limit.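

In this assay, placing 3-bromophenyl in place of 4-fluorophenyl on a carbonyl carbon gives an at least 1.3-fold higher number from compound 3 to compound 4 (0.14 log units; that floor lies within the scatter). Going by these compounds alone, this is the first step that can be read at this position, yet it is only a floor, so its true size remains unknown. The step from compound 1 to compound 4, fluoro in place of hydrogen on an aromatic carbon, cannot be read, and compound 3 remains the only compound with a number, the others sharing one limit: the limit of > 100000 nM in this assay, at which 3 of the 4 values shown sit.

As far as these compounds go, how much weaker compound 4 really is than compound 3 stays open, as does any contribution of the fluoro on an aromatic carbon. The compounds shown also do not tell how a methoxy group or an amine on the phenyl ring at that carbonyl carbon would read out.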